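Aryl piperazine exchange and receptor binding

A few compounds are considered here, and "the series" means these few. Any claim that something is new, unique, unknown or untested is made for them only; others in the source may bear on it.

For the measured compounds named here, compound 2 `COC(=O)C1=C(C)NC(=O)N(C(=O)NCCCN2CCN(c3cccc([N+](=O)[O-])c3)CC2)C1c1ccc(F)c(F)c1` gives 12 nM in an assay on liver for binding affinity to Alpha-1A adrenergic receptor (Homo sapiens), using microsomes (a higher number here means a weaker inhibitor, a lower number a stronger inhibitor), and stands highest of the two numbers measured so far. Going by the values given here, compound 1 `COC(=O)C1=C(C)NC(=O)N(C(=O)NCCCN2CCN(c3ccccc3O)CC2)C1c1ccc(F)c(F)c1` gives 0.6 nM in this assay; the only step measured, a 20-fold higher number from compound 1 to compound 2 (1.30 log units; beyond the scatter), separates the two. Compound 3 `COC(=O)C1=C(C)NC(=O)N(C(=O)NCCCN2CCN(c3ccccc3Cl)CC2)C1c1ccc(F)c(F)c1` is not yet measured. It differs from compound 2 in one place: 2-chlorophenyl in place of 3-nitrophenyl on an amine nitrogen in a ring. Among the compounds with values here, no measured step covers this exact exchange. The step that bears on it is a 20-fold higher number from compound 1 to compound 2 (1.30 log units; beyond the scatter), which shows that replacing a 2-hydroxyphenyl by a 3-nitrophenyl on the amine nitrogen in the ring moves the number by a large amount. Compound 3 carries a 2-chlorophenyl at that nitrogen, a group with 0 hydrogen-bond donors and 0 hydrogen-bond acceptors, so only a partial return toward the number of compound 1 is expected. Compound 3 is expected to fall between the two measured numbers, at 2 nM in this assay, with a range from 0.5 nM to 8 nM. For compound 3 this means an expected step of a 6.0-fold lower number from compound 2 to compound 3 (0.78 log units; beyond the scatter).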

Compound 3, inhibition constant: 0.2 nM
The estimate for compound 3 lay 10-fold (1.00 log units) above the measured number; measured number outside the range, below it.
By their numbers in this assay, from the lowest: compound 3; then compound 1; then compound 2.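

Within this assay, a low number at the amine nitrogen of the ring does not depend on a hydroxy group: chloro in place of hydroxy on the aromatic carbon gives a 3.0-fold lower number from compound 1 to compound 3 (0.48 log units; beyond the scatter) and places a group with 0 hydrogen-bond donors at the low end of the series. The exchange of the 3-nitrophenyl for the 2-chlorophenyl gives the largest step yet seen here (a 60-fold lower number from compound 2 to compound 3 (1.78 log units; beyond the scatter)), so compound 2 stands apart from the two compounds that carry a substituted phenyl of the 2- type, though this step changes both the substituent and where it sits on the phenyl, and the two changes cannot be separated. No measurement at hand gives a reason for either step.

Still open, from the compounds shown here alone, is whether the high number of compound 2 follows from the nitro group or from its place on the phenyl, a question that a 3-chlorophenyl or a 2-nitrophenyl on the same nitrogen would address. Also open, going by these compounds, is how far the order of these aryl groups holds with a 2-methoxyphenyl at this nitrogen or with a longer chain in place of the propyl linker.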